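The source may report more compounds than this note shows. Statements on the series, on what has been measured and on what is new or still open speak of the compounds shown alone.

Measured so far, in an ADME assay on MT4 cells (Homo sapiens) for cytotoxicity, read by MTT assay, with a stated time of 5 days; a lower number here means that less compound is tolerated, a higher number that more compound is tolerated:
Compound 1, `CN(c1ccnc(Nc2ccc(C#N)cc2)n1)c1c(F)cc(-c2ccc(C#N)cc2)cc1F`: 148000 nM
Compound 2, `CCN(c1ccnc(Nc2ccc(C#N)cc2)n1)c1c(F)cc(-c2ccc(C#N)cc2)cc1F`: 105000 nM
Compound 3, `CCC(C)CN(c1ccnc(Nc2ccc(C#N)cc2)n1)c1c(F)cc(-c2ccc(C#N)cc2)cc1F`: a limit, > 255000 nM

Compound 2 and compound 1 lie within the scatter of each other, the step being a 1.4-fold lower number from compound 1 to compound 2 (0.15 log units; within the scatter). Compound 3 reaches only a limit in this assay (the limit of > 255000 nM in this assay, at which 1 of the 3 values shown sits). Compound 4, `C=CCN(c1ccnc(Nc2ccc(C#N)cc2)n1)c1c(F)cc(-c2ccc(C#N)cc2)cc1F`, differs from compound 2 by vinyl in place of methyl on a saturated chain carbon bound to a nitrogen on an aromatic ring. Two steps at the same place bear on it: a 1.4-fold lower number from compound 1 to compound 2 (0.15 log units; within the scatter) and an at least 2.4-fold higher number from compound 2 to compound 3 (0.38 log units; beyond the scatter). Vinyl in place of methyl is a smaller growth than sec-butyl in place of methyl, so only a small rise, possibly none beyond the scatter, is expected, the estimated step being a 1.2-fold higher number from compound 2 to compound 4 (0.09 log units; within the scatter). Compound 4 is thus expected to give about 130000 nM, between 70000 nM and 250000 nM.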

Compound 4, half-maximal cytotoxic concentration: 249000 nM
Compound 4: the middle estimate sits 1.9-fold (0.28 log units) below what was measured, and the stated range covers the measured number.
By their numbers in this assay, from the lowest: compounds 2, 1 and 4 (each within the scatter of the next, the first and the last beyond it). At a limit, above all of these: compound 3.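

In this assay, this place on a saturated chain carbon bound to a nitrogen on an aromatic ring now shows a rise beyond the scatter with a small unbranched group, as vinyl replaces methyl (a 2.4-fold higher number from compound 2 to compound 4 (0.38 log units; beyond the scatter)). Compound 4 stays within the scatter of compound 1 (a 1.7-fold higher number from compound 1 to compound 4 (0.23 log units; within the scatter)), and only a floor can be read against compound 3 (an at least 1.0-fold lower number from compound 3 to compound 4 (0.01 log units; that floor lies within the scatter)). The value of compound 3 is a limit: the limit of > 255000 nM in this assay, at which 1 of the 4 values shown sits.

The compounds shown leave open whether propyl here would match compound 4, which would show whether the double bond plays any part. From the compounds shown here alone, how an amine or a carboxylic acid at this place would read also remains open.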